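Alkyne substituent swap on the shared core

The compounds below may be only part of what the source reports. "The series", "measured", "known", "first", "only" and "open" are said of these compounds alone.

compound 1 `O=c1nc2c(cn1Cc1ccccc1)ncn2Cc1ccccc1`: > 10 ug/mL
compound 2 `O=c1nc2c(ncn2Cc2ccccc2)c(C#Cc2ccccc2)n1Cc1ccccc1`: 1 ug/mL

In a functional assay on K562 cells (Homo sapiens), read by thymidine incorporation, with a stated time of 5 h (a higher number here means a weaker inhibitor, a lower number a stronger inhibitor), compound 1 gives > 10 ug/mL, which is a limit of the assay and not a number. Compound 2 gives 1 ug/mL in this assay and is the only number shown. Among the measured compounds shown here, the single measured step, an at least 10-fold lower number from compound 1 to compound 2 (1.00 log units; beyond the scatter), shows that a group on the triple-bonded carbon lowers the number markedly. Compound 3 `O=c1nc2c(ncn2Cc2ccccc2)c(C#CC2CC2)n1Cc1ccccc1` differs from compound 2 by cyclopropyl in place of phenyl on a triple-bonded carbon. For the measured compounds named here, no measured step compares two groups at that position, so the direction is uncertain. Compound 3 is expected to give about 3 ug/mL in this assay, between 1 ug/mL and 10 ug/mL. The expected step of a 3.0-fold higher number from compound 2 to compound 3 (0.48 log units; beyond the scatter) is thus a modest rise in number.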

Compound 3, half-maximal inhibitory concentration: 0.4 ug/mL
Compound 3: the middle estimate sits 7.5-fold (0.88 log units) above what was measured, outside the stated range (below it).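

In this assay, the group on the triple-bonded carbon need not be aromatic: cyclopropyl in place of phenyl gives a 2.5-fold lower number from compound 2 to compound 3 (0.40 log units; beyond the scatter). Against hydrogen on the aromatic carbon, 2-cyclopropylethynyl gives an at least 25-fold lower number from compound 1 to compound 3 (1.39 log units; beyond the scatter). The size of that step rests on the value of compound 1, which is a limit of the assay and not a number: the limit of > 10 ug/mL in this assay, at which 1 of the 3 values shown sits.

As far as these compounds go, whether cyclobutyl, a longer alkyl chain or an amine on the triple-bonded carbon would lower the number further stays open. Among the compounds shown here, only two groups can be compared at that place, so no trend with group size can be read.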